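Cyclopentyl for Ethyl on the Hydroxyurea Nitrogen

The source may hold more compounds than are shown below. What is called first, only, known or untested is meant among the compounds shown, and "the series" means these compounds.

Compound 1 `Cc1nc(-c2c(F)cc(Cl)cc2-c2cnc([C@@H](C)NC(=O)N(C)O)c(F)c2)no1`: 1.2 nM
Compound 2 `Cc1nc(-c2c(F)cccc2-c2cnc([C@@H](C)NC(=O)N(C)O)c(F)c2)no1`: 31 nM
Compound 3 `CCN(O)C(=O)NCc1ncc(-c2cc(Cl)cc(F)c2-c2nnn(C)n2)cc1F`: 4.6 nM

In a functional assay on IMR-90 cells for antagonist activity at B1 bradykinin receptor (Homo sapiens), read by calcium flux (on this read-out higher numbers stand for weaker inhibition and lower numbers for stronger inhibition), compound 3 gives 4.6 nM, the second highest of the three numbers. Compound 1 gives 1.2 nM, and compound 2 gives 31 nM. Among the compounds with values here, the only step between these two is a 26-fold higher number from compound 1 to compound 2 (1.41 log units; beyond the scatter), which concerns hydrogen in place of chloro on an aromatic carbon.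

Compound 4 `Cn1nnc(-c2c(F)cc(Cl)cc2-c2cnc(CNC(=O)N(O)C3CCCC3)c(F)c2)n1` differs from compound 3 by cyclopentyl in place of ethyl on an amide-type nitrogen. Within the data shown here, no measured step bears on that nitrogen, so the size and direction of the change are not anchored by the measured compounds. The expectation is therefore a step of about a 1.2-fold lower number from compound 3 to compound 4 (0.06 log units; within the scatter), within or close to the scatter. Compound 4 is estimated at 4 nM, with a range from 1 nM to 20 nM.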

Compound 4, half-maximal inhibitory concentration: 0.8 nM
Estimate against measurement, compound 4: 5.0-fold (0.70 log units) above; measured number outside the range, below it.
By their numbers in this assay, from the lowest: compounds 4 and 1 (each within the scatter of the next); then compound 3; then compound 2.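

In this assay the amide-type nitrogen proves open to change: a 5.8-fold lower number from compound 3 to compound 4 (0.76 log units; beyond the scatter) comes with cyclopentyl in place of ethyl, so a larger group with a five-membered ring is accepted there and inhibition grows stronger. Within the data shown here, this is the first measured step at that nitrogen, since the earlier step concerned only an aromatic carbon. No evidence is available to explain the gain. On these data alone, whether a six-membered cyclohexyl or a longer chain such as butyl would do as well stays open, as does whether cyclopentyl would bring a similar step on the core of compound 1.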